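This account rests on a few compounds, and the source may have more. Where it says the series, first, only, none or still open, it means among the compounds named here.

Measured so far:
compound 1, `N=C(NCCCc1c[nH]cn1)NCCCC(c1ccc(F)cc1)c1ccccn1`, 6.87
compound 2, `N=C(NCCCc1c[nH]cn1)NCCC(c1ccc(F)cc1)c1ccccn1`, 8.01
compound 3, `N=C(NCCCc1c[nH]cn1)NCCC(c1cccc(F)c1)c1ccccn1`, 7.88

In a functional assay on cardiac atrium for agonist activity at histamine H2 receptor (Cavia porcellus) (on this read-out lower numbers stand for lower potency and higher numbers for higher potency (the scale is a negative logarithm)), compound 3 gives 7.88. It sits at the upper end of the three numbers together with compound 2, the two separated only by the step of a number 0.13 log units lower from compound 2 to compound 3 (within the scatter), which is within the scatter. Going by the values given here, compound 1 lies furthest away, lower by a margin beyond the scatter; no single-change step joins compound 1 to compound 3, so the two values are simply read side by side.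

Compound 4, `N=C(NCCCc1c[nH]cn1)NCCC(c1ccccn1)c1cccs1`, differs from compound 3 in one place: thiophen-2-yl in place of 3-fluorophenyl on a saturated chain carbon bound to an aromatic carbon and a saturated chain carbon. Among the compounds with values here, the only measured step at this position is a number 0.13 log units lower from compound 2 to compound 3 (within the scatter), an exchange of one fluorophenyl for another, and it stayed within the scatter. Within the data shown here, no measured compound carries thiophen-2-yl, so the change has no direct precedent in this assay. Among the measured compounds shown here, the one comparable aryl exchange suggests that variation at this position is tolerated, and the step of a number 0.08 log units lower from compound 3 to compound 4 (within the scatter) is therefore expected to be small, with no clear direction beyond the scatter. Compound 4 is estimated at 7.8, with a range from 7.2 to 8.4.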

Compound 4, negative logarithm of the half-maximal effective concentration: 7.16
The estimate for compound 4 lay 0.64 log units above the measured number; measured number outside the range, below it.
By their numbers in this assay, from the lowest: compounds 1 and 4 (each within the scatter of the next); then compounds 3 and 2 (each within the scatter of the next).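

In this assay, this position on a saturated chain carbon bound to an aromatic carbon and a saturated chain carbon now proves sensitive to the choice of aromatic group. The exchange of one fluorophenyl for the other had stayed within the scatter, with a number 0.13 log units lower from compound 2 to compound 3 (within the scatter), but thiophen-2-yl takes the number down by a margin beyond the scatter from either fluorophenyl compound, with a number 0.72 log units lower from compound 3 to compound 4 (beyond the scatter) and a number 0.85 log units lower from compound 2 to compound 4 (beyond the scatter). The position therefore tolerates a change in where the fluorine sits on the six-membered aromatic ring of carbon only, but not, without loss, the exchange of that ring for a five-membered aromatic ring with a sulfur atom, and nothing available accounts for this loss.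

This single exchange alters ring size, the fluorine and the sulfur together, so the compounds shown do not separate their contributions, and unsubstituted phenyl, thiophen-3-yl or furan-2-yl at this position would each bear on that question. Also open, as far as these compounds go, is whether thiophen-2-yl would lower the number to a similar extent on the longer chain of compound 1.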